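Arylhydrazone series on a shared core: notes on compound 4

This account rests on a few compounds, and the source may have more. Where it says the series, first, only, none or still open, it means among the compounds named here.

Measured compounds in a functional assay on the whole organism for inhibition, with Rattus norvegicus as the target; on this read-out higher numbers stand for an effect only at larger amounts of compound and lower numbers for an effect already at smaller amounts:

Compound 1 `CC1CC/C(=N\Nc2ccc(F)cc2)c2ncc(C(=O)O)c(=O)n21` gives only a limit of the assay, > 1000 umol/kg.
Compound 2 `COc1ccccc1N/N=C1\CCC(C)n2c1ncc(C(=O)O)c2=O` likewise gives only a limit, > 1000 umol/kg.
Compound 3 `CCc1ccc(N/N=C2\CCC(C)n3c2ncc(C(=O)O)c3=O)cc1` also gives only a limit, > 1000 umol/kg.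

Compound 2 therefore stands nowhere in particular on the numbers shown: its value is a limit and not a number, and the two other values shown for comparison are limits as well. The three measured compounds sit together at the same point, (the limit of > 1000 umol/kg in this assay, at which 3 of the 3 values shown sit), so no ordering among them can be read.

The measured steps are accordingly uninformative. The step that the two limits leave unreadable from compound 1 to compound 2 and the step that the two limits leave unreadable from compound 1 to compound 3 are both unreadable, as is the step that the two limits leave unreadable from compound 2 to compound 3. None of them gives a size or a direction.

Compound 4 `CC1CC/C(=N\Nc2ccccc2CCO)c2ncc(C(=O)O)c(=O)n21` differs from compound 2 by 2-hydroxyethyl in place of methoxy on an aromatic carbon. Since every variation of the aryl group on the hydrazine nitrogen so far has left the value at the limit, no step beyond the scatter can be expected for this change either, and the most likely outcome is again a limit in this assay. The estimate for compound 4 is 2000 umol/kg, with a range of 600 umol/kg to 6000 umol/kg, which means an expected step that the limit leaves unreadable from compound 2 to compound 4.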

Compound 4, dose for 50% inhibition: > 100 umol/kg
Compound 4: only a limit was reported; the forecaster's own chance of this, stated with the estimate: 80%; the middle value does not contradict the limit.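

Compound 4 gives only a limit, > 100 umol/kg, and compound 2 is likewise held at a limit, so no step can be read between compound 2 and compound 4. The compounds shown leave open whether 2-hydroxyethyl in place of methoxy changes the dose in this assay at all, and how the four compounds rank.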